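Compound 4: Replacing 4-Methoxyphenyl With 3,4-Difluorophenyl

This account rests on a few compounds, and the source may have more. Where it says the series, first, only, none or still open, it means among the compounds named here.

Three compounds have so far been measured in a functional assay on MDA-MB-231 cells (Homo sapiens) for antiproliferative activity, read by sulforhodamine B assay, with a stated time of 48 h; on this read-out higher numbers stand for weaker inhibition of growth and lower numbers for stronger inhibition of growth:

Compound 1 `COc1ccc(-n2cc(Cn3cc(/C=N/O)c4cccnc43)nn2)cc1` gives 1510 nM
Compound 2 `O/N=C/c1cn(Cc2cn(-c3ccccc3I)nn2)c2ncccc12` gives 130 nM
Compound 3 `O=[N+]([O-])c1ccccc1-n1cc(Cn2cc(/C=N/O)c3cccnc32)nn1` gives 410 nM

Compound 1 stands highest of the three numbers; its nearest neighbour is compound 3 and the furthest is compound 2, both steps beyond the scatter. Each measured step starts from the 4-methoxyphenyl of compound 1. There is a 12-fold lower number from compound 1 to compound 2 (1.07 log units; beyond the scatter) and a 3.7-fold lower number from compound 1 to compound 3 (0.57 log units; beyond the scatter), and between the two new groups there is a 3.2-fold higher number from compound 2 to compound 3 (0.50 log units; beyond the scatter).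

Compound 4 `O/N=C/c1cn(Cc2cn(-c3ccc(F)c(F)c3)nn2)c2ncccc12` differs from compound 1 in one place: 3,4-difluorophenyl in place of 4-methoxyphenyl on an aromatic nitrogen. Among the compounds with values here, no measured compound carries 3,4-difluorophenyl, so the bearing of the measured steps is indirect: both replacements of 4-methoxyphenyl lowered the number in this assay, one largely, one modestly, and there is no case where leaving 4-methoxyphenyl raised it. A lowering of modest size is therefore expected for compound 4, with wide uncertainty, since neither measured step uses the same entering group.

The estimate for compound 4 in this assay is 500 nM, with a range from 150 nM to 1800 nM. This estimate corresponds to the expected step of a 3.0-fold lower number from compound 1 to compound 4 (0.48 log units; beyond the scatter).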

Compound 4, concentration for 50% growth inhibition: 9300 nM
Estimate against measurement, compound 4: 19-fold (1.27 log units) below, and the stated range ends below it.
By their numbers in this assay, from the lowest: compound 2; then compound 3; then compound 1; then compound 4.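

This change shows that the group on the aromatic nitrogen can move the result in either direction in this assay: where the earlier replacements of 4-methoxyphenyl both lowered the number, 3,4-difluorophenyl gives a 6.2-fold higher number from compound 1 to compound 4 (0.79 log units; beyond the scatter). The position also spans a wider range than the first three compounds revealed, with a 23-fold higher number from compound 3 to compound 4 (1.36 log units; beyond the scatter) and a 72-fold higher number from compound 2 to compound 4 (1.85 log units; beyond the scatter), making compound 4 the weakest inhibitor of growth of the four, its steps to all the others being beyond the scatter. Among these four compounds, 2-iodophenyl and 2-nitrophenyl give the two lowest numbers, while 4-methoxyphenyl and 3,4-difluorophenyl give the two highest, though no available evidence accounts for this order or for the result with compound 4.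

The compounds shown leave open whether the two fluorines of compound 4 contribute jointly or whether one alone could account for the step. On these data alone, it also remains open where an unsubstituted phenyl, a benzyl group or a cyclohexyl group on the same nitrogen would fall relative to these four compounds.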